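The source may hold more compounds than are shown below. What is called first, only, known or untested is meant among the compounds shown, and "the series" means these compounds.

Measured compounds:
compound 1 `O=[N+]([O-])c1ccc(-c2csc(N3N=C(c4ccc(N5CCCCC5)cc4)CC3c3ccc(Cl)cc3)n2)cc1`; compound 2 `Clc1ccc(C2CC(c3ccc(N4CCCCC4)cc3)=NN2c2nc(-c3ccc(Br)cc3)cs2)cc1`; compound 3 `N#Cc1ccc(-c2csc(N3N=C(c4ccc(N5CCCCC5)cc4)CC3c3ccc(Cl)cc3)n2)cc1`.

In a functional assay on A-375 cells (Homo sapiens) for antiproliferative activity, read by MTT assay, with a stated time of 72 h (on this read-out lower numbers stand for stronger inhibition and higher numbers for weaker inhibition), compound 1 gives only a limit, > 100000 nM. Compound 2 likewise gives only a limit, > 100000 nM. Among the compounds with values here, compound 3 gives 38700 nM, the only number among the three. Both measured steps toward compound 3 point the same way, an at least 2.5-fold lower number from compound 1 to compound 3 (0.41 log units; beyond the scatter) and an at least 2.5-fold lower number from compound 2 to compound 3 (0.41 log units; beyond the scatter), each bounded by the limit of > 100000 nM in this assay, at which 2 of the 3 values shown sit.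

Compound 4 `Clc1ccc(C2CC(c3ccc(N4CCCCC4)cc3)=NN2c2nc(-c3ccc4ccccc4c3)cs2)cc1` is not yet measured. Its change from compound 3: naphthalen-2-yl in place of 4-cyanophenyl on an aromatic carbon. The 4-cyanophenyl group, the only one of the three aryl groups that gave a readable number, leaves, and no acceptor enters. The two bounded steps suggest a weaker number for compound 4. Compound 4 is thus expected to show a step of a 2.1-fold higher number from compound 3 to compound 4 (0.32 log units; beyond the scatter), with a fair chance of a limit rather than a number. The estimate for compound 4 is 80000 nM, range 25000 nM to 200000 nM.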

Compound 4, half-maximal inhibitory concentration: > 100000 nM
Compound 4 was reported as a limit; the forecaster's own chance of this, stated with the estimate: 45%; at least 1.2-fold (0.09 log units) between middle value and limit.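

In this assay, the aryl group on the aromatic carbon next to the ring nitrogen was changed, and naphthalen-2-yl in place of 4-cyanophenyl gives an at least 2.5-fold higher number from compound 3 to compound 4 (0.41 log units; beyond the scatter). A second aromatic ring therefore does not keep a readable number here, and among the four aryl groups shown only the 4-cyanophenyl of compound 3 does so. The steps among compound 1, compound 2 and compound 4 cannot be read, as each of these is reported only as a limit: the limit of > 100000 nM in this assay, at which 3 of the 4 values shown sit.

As far as these compounds go, whether a 4-aminophenyl or 4-carboxyphenyl group on this carbon would give a lower number than compound 3 stays open. So does what a small group such as methyl would give there.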